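Carboxymethyl for carboxy on the trifluoromethyl benzoyl acid

The source may hold more compounds than are shown below. What is called first, only, known or untested is meant among the compounds shown, and "the series" means these compounds.

Compound 2 `O=C(O)c1ccc2ccc(C(=O)c3ccc(C(F)(F)F)cc3)c-2cc1` gives -81.5% in an assay on cells for displacement of a labelled ligand from Orexin/Hypocretin receptor type 1 (Homo sapiens), read by scintillation counting, with stated times of 10 min and 90 min, tested at 10 uM (a lower number here means less inhibition, a higher number more inhibition at the concentration tested (going by the name of the read-out)), the lowest of the three numbers recorded. Compound 1 `O=C(O)c1ccc2ccc(C(=O)c3ccccc3)c-2cc1` gives 11% and compound 3 `O=Cc1ccc2ccc(C(=O)O)ccc1-2` gives 37.8%, both beyond the scatter above compound 2. The two measured steps are a number 92.5 percentage points lower from compound 1 to compound 2 (beyond the scatter), a large fall, and a number 26.8 percentage points higher from compound 1 to compound 3 (beyond the scatter), a modest rise; both alter the ketone side of the shared core and leave the acid untouched.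

Compound 4 `O=C(O)Cc1ccc2ccc(C(=O)c3ccc(C(F)(F)F)cc3)c-2cc1` is the unmeasured member. Its change from compound 2 is carboxymethyl in place of carboxy on an aromatic carbon. Among the compounds with values here, no measured step touches the acid, so the two steps give no direct guide to the size or direction of this change; they only show that the series spans a wide range of read-outs. The expected step for compound 4 is therefore small and uncertain, a number 31.5 percentage points higher from compound 2 to compound 4 (beyond the scatter), weighted a little toward the readings of compound 1 and compound 3 since the negative reading of compound 2 stands apart. Compound 4 is estimated at -50%, within -100% to 0%.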

Compound 4, a percentage reported as inhibition, at one concentration (the size of the read-out at that concentration, not a potency): 8.6%
The estimate for compound 4 lay 58.6 percentage points below the measured number; the measured number lies above the stated range.
By their numbers in this assay, from the lowest: compound 2; then compounds 4 and 1 (each within the scatter of the next); then compound 3.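

Carboxymethyl in place of carboxy on an aromatic carbon gives a number 90.1 percentage points higher from compound 2 to compound 4 (beyond the scatter) in this assay, a large step and the only measured change on the acid side of the shared core. This position is therefore not silent: with the trifluoromethyl benzoyl side held fixed, compound 2 gives -81.5% and compound 4 gives 8.6%, so a change at the acid alone takes the number from negative to positive. Nothing on hand explains this step, and no measurement here assigns a property to either group.

On these data alone, whether the same change has a similar effect on the unsubstituted benzoyl compound 1 remains open. Also open, as far as these compounds go, is whether a longer chain ending in a carboxylic acid, or an amide in place of that acid, would move the number further in the same direction.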